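This account rests on a few compounds, and the source may have more. Where it says the series, first, only, none or still open, it means among the compounds named here.

Compound 1 `Cc1ccc2nc(Nc3nc(Nc4ccc(S(C)(=O)=O)cc4)ncc3F)sc2c1` serves as the starting point of this series. In a functional assay on MDA-MB-231 cells (Homo sapiens) for antiproliferative activity, read by MTT assay, with a stated time of 48 h (a higher number here means a weaker inhibitor, a lower number a stronger inhibitor), compound 1 gives 14300 nM. Compound 2 `CS(=O)(=O)c1ccc(Nc2ncc(F)c(Nc3nc4ccc(F)cc4s3)n2)cc1` differs from it in one place, (fluoro in place of methyl on an aromatic carbon), and in this assay compound 2 gives 8900 nM. The step of a 1.6-fold lower number from compound 1 to compound 2 (0.21 log units; within the scatter) is therefore small.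

Compound 3 `COc1ccc2nc(Nc3nc(Nc4ccc(S(N)(=O)=O)cc4)ncc3C)sc2c1` carries a different core, and the difference between the two cores is not broken down here. For compound 3 this assay reports only a limit, > 50000 nM; this is the limit of > 50000 nM in this assay, at which 1 of the 3 values shown sits.

Compound 4 `COc1ccc2nc(Nc3nc(Nc4ccc(S(N)(=O)=O)cc4)ncc3F)sc2c1` is not yet measured. Within the data shown here, it is related to compound 3 by fluoro in place of methyl on an aromatic carbon, the same kind of change as the one from compound 1 to compound 2, but the place is not the same: there it sat on a six-membered aromatic ring of carbon only, part of a fused or bridged system of two rings, meta to a fused ring and para to a fused ring, whereas here it sits on a six-membered aromatic ring with 2 nitrogen, ortho to a large group, two atoms from the ring nitrogen and para to a large group. Since compound 3 shows only a limit, the step to compound 4 can only be estimated; resting on a 1.6-fold lower number from compound 1 to compound 2 (0.21 log units; within the scatter), which was small, compound 4 is expected to move by an at least 1.6-fold lower number from compound 3 to compound 4 (0.22 log units; that floor lies within the scatter). The value expected for compound 4 in this assay is 30000 nM, between 8000 nM and 100000 nM.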

Compound 4, half-maximal inhibitory concentration: 26600 nM
Compound 4: the middle estimate sits 1.1-fold (0.05 log units) above what was measured; low and high end bracket the measured number.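

In this assay, fluoro in place of methyl on an aromatic carbon of the six-membered aromatic ring with 2 nitrogen gives an at least 1.8-fold lower number from compound 3 to compound 4 (0.27 log units; that floor lies within the scatter). Set beside the earlier case, where the same change sat on a six-membered aromatic ring of carbon only, the two steps point the same way, but the comparison stays open: the same change on two cores in this assay, a 1.6-fold lower number (0.21 log units; within the scatter) from compound 1 to compound 2 and an at least 1.8-fold lower number (0.27 log units; that floor lies within the scatter) from compound 3 to compound 4; the limit leaves it open whether they differ

Going by these compounds, compound 3 has only a limit, > 50000 nM, and the true size of this step remains unknown; the two pairs show neither that the change carries over from one core to another with the same size nor that it does not, and two cores set no rule for the rest of the series.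

The compounds shown leave open whether another group on that aromatic carbon, such as chloro, a nitrile or an amine, would move the number in this assay beyond the scatter. Among these compounds, they also leave open what each of the other differences between the core of compound 1 and the core of compound 3 contributes, as no pair here changes any of them singly.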